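Swapping the aryl amide for a chloropyridine

The source may report more compounds than this note shows. Statements on the series, on what has been measured and on what is new or still open speak of the compounds shown alone.

Compounds measured so far in an assay on HEK cells for inhibition of Tryptophan 2,3-dioxygenase (Homo sapiens); on this read-out higher numbers stand for weaker inhibition and lower numbers for stronger inhibition:
compound 1 `O=C(Nc1ccc(Cl)cc1)C(=O)N1CCC(c2ccnc3ccc(F)cc23)CC1` — 6900 nM
compound 2 `O=C(Nc1ccc(C(F)(F)F)cc1)C(=O)N1CCC(c2ccnc3ccc(F)cc23)CC1` — 9500 nM

Compound 2 carries the highest of the two numbers, yet the step of a 1.4-fold higher number from compound 1 to compound 2 (0.14 log units; within the scatter) is within the scatter, so the two compounds cannot be told apart on this read-out. Compound 3 `O=C(Nc1ccc(Cl)cn1)C(=O)N1CCC(c2ccnc3ccc(F)cc23)CC1` has not been measured. It differs from compound 2 at one place: 5-chloropyridin-2-yl in place of 4-(trifluoromethyl)phenyl on an amide-type nitrogen. Going by the values given here, no measured step bears on this change. Among the compounds with values here, the only step available, a 1.4-fold higher number from compound 1 to compound 2 (0.14 log units; within the scatter), alters a substituent on the aromatic ring while keeping a carbon-only ring, and it did not move the number beyond the scatter. There is thus no footing for expecting a clear shift in either direction, and the expectation for compound 3 is a number close to that of compound 2, a 1.2-fold lower number from compound 2 to compound 3 (0.07 log units; within the scatter), with wide uncertainty. The estimate for compound 3 is 8000 nM, ranging from 2500 nM to 25000 nM.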

Compound 3, half-maximal inhibitory concentration: 5900 nM
Compound 3: the middle estimate sits 1.4-fold (0.13 log units) above what was measured; the measured number falls inside the stated range.
By their numbers in this assay, from the lowest: compounds 3, 1 and 2 (each within the scatter of the next).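

In this assay, the 5-chloropyridin-2-yl group on the amide-type nitrogen gives a 1.6-fold lower number from compound 2 to compound 3 (0.21 log units; within the scatter) and, compared with the 4-chlorophenyl group, a 1.2-fold lower number from compound 1 to compound 3 (0.07 log units; within the scatter). The second step is the closer comparison: the chlorine stays, and a ring of carbon only gives way to a ring with one hetero atom, which brings a hydrogen-bond acceptor. This position therefore accepts a ring with a hetero atom as well as carbon-only rings, with no difference that can be told from scatter, and no supporting evidence bears on this result.

As far as these compounds go, whether an amine or a carboxylic acid on this ring, or a longer chain in its place, would move the number beyond the scatter remains open. All three compounds share one core, so the effect of changes there is also unknown.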